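Fluorine placement on a stilbene series: activation read-out

The source may report more compounds than this note shows. Statements on the series, on what has been measured and on what is new or still open speak of the compounds shown alone.

Measured compounds:
compound 1 `Cc1ccc(/C=C/c2ccc(F)cc2)cc1`, 1300 nM
compound 2 `Cc1ccc(/C=C/c2ccc(F)c(F)c2)cc1`, 2600 nM
compound 3 `Fc1cccc(/C=C/c2cccc(F)c2)c1`, 1000 nM

The read-out is an assay on HepG2 cells for activation of nuclear factor erythroid 2-related factor 2 (Homo sapiens), read by a luciferase reporter, with a stated time of 5 h; on this read-out higher numbers stand for an effect only at larger amounts of compound and lower numbers for an effect already at smaller amounts. Compound 1 gives 1300 nM and compound 2 gives 2600 nM; the change between them is fluoro in place of hydrogen on an aromatic carbon, and it made a step of a 2.0-fold higher number from compound 1 to compound 2 (0.30 log units; within the scatter). Compound 3 gives 1000 nM, within the scatter of compound 1 and beyond it only against compound 2. The difference between the core of compound 3 and the core of compound 1 is not broken down here.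

Compound 4 `Fc1cccc(/C=C/c2cc(F)ccc2F)c1` is not yet measured. It differs from compound 3 by fluoro in place of hydrogen on an aromatic carbon. This is the same kind of change as that from compound 1 to compound 2, but the surroundings differ: in the earlier case the new fluoro sits ortho to a fluoro group and meta to a group of 9 heavy atoms, here it sits ortho to a group of 9 heavy atoms and para to a fluoro group. Within the data shown here, the expectation for compound 4 rests on the one earlier step, so an estimated step of a 1.8-fold higher number from compound 3 to compound 4 (0.26 log units; within the scatter) in this assay seems reasonable. On that basis compound 4 is expected to give about 1800 nM, with a likely range from 800 nM to 4000 nM.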

Compound 4, half-maximal effective concentration: 300 nM
Compound 4: the middle estimate sits 6.0-fold (0.78 log units) above what was measured; the whole stated range lies above it.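

In this assay, fluoro in place of hydrogen on an aromatic carbon gives a 3.3-fold lower number from compound 3 to compound 4 (0.52 log units; beyond the scatter), so on this core the change goes with a lower number, and the step lies beyond the scatter. Set beside the earlier step, the same change does not carry over from one core to the other in either direction or size: the same change on two cores in this assay, a 2.0-fold higher number (0.30 log units; within the scatter) from compound 1 to compound 2 and a 3.3-fold lower number (0.52 log units; beyond the scatter) from compound 3 to compound 4, 6.7-fold (0.82 log units) apart, beyond the scatter of two such steps. This shows that a step read on one core cannot simply be transferred to another in this series, but with one pair per core it does not show whether the new place of the fluoro or the rest of the core accounts for the gap, and it gives no general rule.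

Open, going by these compounds, is whether a fluoro ortho to a group of 9 heavy atoms would give a similar step on the core of compound 1. The compounds shown carry only fluoro and methyl groups, which leaves open how a chloro, a methoxy group, an amine or a carboxylic acid at that place would compare.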